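Trimming a Methoxy to a Methyl at a Carbonyl

The source may report more compounds than this note shows. Statements on the series, on what has been measured and on what is new or still open speak of the compounds shown alone.

Compound 1 `CC(C)c1nc2c(C(=O)NCC3CCN(CCN4CCN(S(C)(=O)=O)CC4)CC3)cccc2[nH]1` gives 0.794 nM in a functional assay for agonist activity at 5-hydroxytryptamine receptor 4 (Homo sapiens), read by cAMP accumulation; on this read-out higher numbers stand for an effect only at larger amounts of compound and lower numbers for an effect already at smaller amounts.
Compound 2 `COC(=O)N1CCN(CCN2CCC(CNC(=O)c3cccc4[nH]c(C(C)C)nc34)CC2)CC1` gives 1.59 nM in this assay.
Compound 3 `COC(=O)N(C)CC(O)CN1CCC(CNC(=O)c2cccc3[nH]c(C(C)C)nc23)CC1` gives 2 nM in this assay.

The three measured compounds share one core and differ only in what hangs from the amine nitrogen in the ring. Compound 3 carries the highest number of the three. One of its gaps is a 1.3-fold higher number from compound 2 to compound 3 (0.10 log units; within the scatter), which sits within the scatter, while the other is a 2.5-fold higher number from compound 1 to compound 3 (0.40 log units; beyond the scatter), a modest but real separation.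

Compound 4 `CC(=O)N(C)CC(O)CN1CCC(CNC(=O)c2cccc3[nH]c(C(C)C)nc23)CC1` keeps the whole of compound 3 except for a single alteration: methyl in place of methoxy on a carbonyl carbon. For the measured compounds named here, none of the measured steps repeats this change. The closest in spirit is a 2.0-fold higher number from compound 1 to compound 2 (0.30 log units; within the scatter), an exchange of one group on the ring amine nitrogen for another, and it stayed within the scatter; a 1.3-fold higher number from compound 2 to compound 3 (0.10 log units; within the scatter) likewise stayed within the scatter. Neither step touched a carbonyl carbon. Going by the values given here, with small movements as the only guide, the step is expected to be a 1.3-fold higher number from compound 3 to compound 4 (0.10 log units; within the scatter), with no direction beyond the scatter. Compound 4 is estimated at 2.5 nM in this assay, with a range from 1 nM to 6.3 nM.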

Compound 4, half-maximal effective concentration: 1.59 nM
Compound 4: the middle estimate sits 1.6-fold (0.20 log units) above what was measured; measured number inside the range.
By their numbers in this assay, from the lowest: compounds 1, 2, 4 and 3 (each within the scatter of the next, the first and the last beyond it).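

At the carbonyl carbon, methyl in place of methoxy gave a 1.3-fold lower number from compound 3 to compound 4 (0.10 log units; within the scatter) in this assay, the first step shown at this place, and the read-out does not separate methoxycarbonyl from acetyl on the amide-type nitrogen. The acetyl compound also sits within the scatter of the two compounds with other groups on the ring amine nitrogen, with no change at the digits printed from compound 2 to compound 4 (within the scatter) and a 2.0-fold higher number from compound 1 to compound 4 (0.30 log units; within the scatter), whereas the methoxycarbonyl version stood apart from the methylsulfonyl compound by a 2.5-fold higher number from compound 1 to compound 3 (0.40 log units; beyond the scatter), so the trim to acetyl leaves that one gap beyond the scatter without a counterpart, though only narrowly, as all of these gaps are small. Nothing measured here bears on why the numbers fall as they do.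

Still open, going by these compounds, is whether a larger group on the carbonyl carbon, such as ethyl or cyclopropyl, or an amino group there, which would make a urea, would move the number beyond the scatter in either direction. Equally open, on these data alone, is what would follow if the hydroxyl on the chain gave way to hydrogen or fluorine, or if hydrogen replaced the methyl on the amide-type nitrogen.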